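The source may report more compounds than this note shows. Statements on the series, on what has been measured and on what is new or still open speak of the compounds shown alone.

Measured so far:
- compound 1 `COc1nc(N)nc2c1c(-c1cccs1)cn2[C@@H]1O[C@H](CO)[C@@H](O)[C@H]1O`: > 100000 nM
- compound 2 `Nc1nc(N)c2c(-c3cccs3)cn([C@@H]3O[C@H](CO)[C@@H](O)[C@H]3O)c2n1`: > 100000 nM
- compound 3 `Nc1nc(N)c2c(-c3cc4ccccc4o3)cn([C@@H]3O[C@H](CO)[C@@H](O)[C@H]3O)c2n1`: 78500 nM

In an ADME assay on MRC5 cells (Homo sapiens), read by MTT assay, with a stated time of 72 h (on this read-out higher numbers stand for weaker inhibition and lower numbers for stronger inhibition), compound 1 gives > 100000 nM, a limit of the assay, not a number. Compound 2 likewise gives only a limit, > 100000 nM. Among the measured compounds shown here, compound 3 is the one compound with a number, 78500 nM. The change methoxy in place of amino on an aromatic carbon made a step that the two limits leave unreadable from compound 2 to compound 1 because of the limit of > 100000 nM in this assay, at which 2 of the 3 values shown sit. The two cores differ by 1-benzofuran-2-yl in place of thiophen-2-yl on an aromatic carbon, which made an at least 1.2-fold lower number from compound 2 to compound 3 (0.10 log units; that floor lies within the scatter).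

Compound 4 `COc1nc(N)nc2c1c(-c1cc3ccccc3o1)cn2[C@@H]1O[C@H](CO)[C@@H](O)[C@H]1O` carries the same change as compound 1, (methoxy in place of amino on an aromatic carbon), on the core of compound 3; the place is described in the same words in both cases. Since the earlier step that the two limits leave unreadable from compound 2 to compound 1 is unreadable, the step from compound 3 to compound 4 is expected to be about a 1.1-fold higher number from compound 3 to compound 4 (0.06 log units; within the scatter), the estimated value for compound 4 being 90000 nM, with 40000 nM to 200000 nM as its expected range.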

Compound 4, half-maximal inhibitory concentration: 22700 nM
Compound 4: middle estimate off by 4.0-fold (0.60 log units), on the high side; measured number below the stated range.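

In this assay, methoxy in place of amino on an aromatic carbon gives a 3.5-fold lower number from compound 3 to compound 4 (0.54 log units; beyond the scatter), while the same change on the other core cannot be read: the limit of > 100000 nM in this assay, at which 2 of the 4 values shown sit.

1-Benzofuran-2-yl in place of thiophen-2-yl gives an at least 4.4-fold lower number from compound 1 to compound 4 (0.64 log units; beyond the scatter), and its size beside the same change on the other core stays unsettled: the same change on two cores in this assay, an at least 1.2-fold lower number (0.10 log units; that floor lies within the scatter) from compound 2 to compound 3 and an at least 4.4-fold lower number (0.64 log units; beyond the scatter) from compound 1 to compound 4; the limit leaves it open whether they differ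

The methoxy step is therefore read on one core only, which shows neither that it carries over to the other core nor that it does not.

Open, as far as these compounds go, is whether an ethoxy or a dimethylamino group in the same place would give a similar step. Also open, from the compounds shown here alone, is whether a phenyl group in place of 1-benzofuran-2-yl would bring the methoxy step into readable range.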